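The compounds below may be only part of what the source reports. "The series", "measured", "known", "first", "only" and "open" are said of these compounds alone.

Working notes on a small set of chlorinated purine benzyl compounds, all tested in a functional assay on LOX IMVI cells (Homo sapiens) for cytotoxicity, read by sulforhodamine B assay, with a stated time of 48 h; on this read-out higher numbers stand for lower toxicity in this test and lower numbers for higher toxicity in this test.

Compound 1 `ClCc1ccc(Cn2cnc3c(Cl)ncnc32)cc1` gives 13500 nM in this assay. Compound 2 `Nc1nc(Cl)c2ncn(Cc3ccc(CCl)cc3)c2n1` carries the same core with amino in place of hydrogen on an aromatic carbon. For compound 2 this assay reports only a limit, > 100000 nM. As far as these compounds go, the step of an at least 7.4-fold higher number from compound 1 to compound 2 (0.86 log units; beyond the scatter) is therefore bounded from one side only, and its true size is unknown beyond that bound; this rests on (the limit of > 100000 nM in this assay, at which 2 of the 3 values shown sit).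

Compound 3 `ClCc1ccccc1Cn1cnc2c(Cl)ncnc21` is built from the same atoms as compound 1, joined differently; the difference between the two cores is not broken down here. For compound 3 this assay again reports only a limit, > 100000 nM.

Compound 4 `Nc1nc(Cl)c2ncn(Cc3ccccc3CCl)c2n1` is not yet measured in this assay. It stands to compound 3 as compound 2 stands to compound 1: amino in place of hydrogen on an aromatic carbon, the same change, at the same place. Going by the values given here, the one measured instance of this change raised the number, from compound 1 to compound 2, to a limit. Compound 3 already sits at that limit, so compound 4 is expected to remain at or beyond it, with an expected step that the limit leaves unreadable from compound 3 to compound 4. For compound 4 the estimate is 200000 nM, expected to lie between 80000 nM and 600000 nM, most likely reported as a limit only.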

Compound 4, concentration lethal to 50% of the cells: > 100000 nM
Compound 4: a limit, no number; the forecaster's own chance of this, stated with the estimate: 85%; the middle value does not contradict the limit.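

The step from compound 3 to compound 4 cannot be read, because each of the two compounds is reported only as a limit: the limit of > 100000 nM in this assay, at which 3 of the 4 values shown sit.

The compounds shown leave open whether amino in place of hydrogen on an aromatic carbon changes anything on the core of compound 3, and how compound 2, compound 3 and compound 4 rank among themselves.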